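This account rests on a few compounds, and the source may have more. Where it says the series, first, only, none or still open, it means among the compounds named here.

Of the compounds shown here, two have been measured so far. Compound 1 `CCOC(=O)N1CCC(N(Cc2cc(Cl)ccc2O)C(=O)N(C)C)CC1` gives 38400 nM in a functional assay on K562 cells (Homo sapiens) for antiproliferative activity, read by MTT assay, with a stated time of 48 h (on this read-out lower numbers stand for stronger inhibition and higher numbers for weaker inhibition), the highest of the two numbers, though compound 2 `CN(C)C(=O)N(Cc1ccc([N+](=O)[O-])cc1)Cc1ccco1` with 35400 nM sits within the scatter of it, so the two show no difference worth the name. Both numbers stand for weak inhibition.

Compound 3 `CCOC(=O)N1CCC(N(Cc2ccc([N+](=O)[O-])cc2)C(=O)N(C)C)CC1` remains to be measured. It differs from compound 1 by 4-nitrophenyl in place of 5-chloro-2-hydroxyphenyl on a saturated chain carbon bound to an amide-type nitrogen. The same 4-nitrophenyl on a saturated chain carbon bound to an amide-type nitrogen is present in compound 2, whose value of 35400 nM lies at the same weak level as compound 1. Going by the values given here, with no measured pair showing a step of this kind, nothing points to a move beyond the scatter; the expected step of a 1.1-fold lower number from compound 1 to compound 3 (0.03 log units; within the scatter) is accordingly small. Compound 3 is estimated at 36000 nM in this assay, with a range from 12000 nM to 100000 nM.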

Compound 3, half-maximal inhibitory concentration: 26000 nM
Compound 3: middle estimate off by 1.4-fold (0.14 log units), on the high side; the range from low to high includes it.
By their numbers in this assay, from the lowest: compounds 3, 2 and 1 (each within the scatter of the next).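

In this assay, the step at this position reads a 1.5-fold lower number from compound 1 to compound 3 (0.17 log units; within the scatter), so this place on a saturated chain carbon bound to an amide-type nitrogen takes either 4-nitrophenyl or 5-chloro-2-hydroxyphenyl without a difference the read-out can separate. The exchange alters the substituents on the aromatic ring and the counts of hydrogen-bond donors and acceptors, yet the number stays within the scatter and the inhibition remains weak. No supporting measurement bears on this result, so it offers no explanation for it.

The exchange changes the chlorine, the hydroxyl and the nitro group together, leaving their separate contributions unresolved. On these data alone, whether an amine, a carboxylic acid or a longer chain at this place would move the number beyond the scatter also remains open.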